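Replacing hydroxy with dimethylamino in compound 2

The source may report more compounds than this note shows. Statements on the series, on what has been measured and on what is new or still open speak of the compounds shown alone.

In a physicochemical assay for solubility, in phosphate buffer, at pH 7.4 (a higher number here means a more soluble compound, a lower number a less soluble compound), compound 2 `OC1CCN(c2nccnc2OC2CN(c3ccc4ccccc4n3)C2)CC1` gives 99000 nM, the second highest of three measured numbers. Compound 1 `OCC1CCN(c2nccnc2OC2CN(c3cnc4ccccc4n3)C2)CC1` stands higher at 500000 nM, and compound 3 `OC1CN(c2nccnc2OC2CN(c3ccc4ccccc4n3)C2)C1` stands lower at 41000 nM.

Compound 4 `CN(C)C1CCN(c2nccnc2OC2CN(c3ccc4ccccc4n3)C2)CC1` has not yet been measured. It carries dimethylamino in place of hydroxy on a saturated ring carbon, a change counted as dimethylamino in place of hydroxy on a saturated ring carbon.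

Among the measured compounds shown here, the only measured step that bears on this is a 2.4-fold lower number from compound 2 to compound 3 (0.38 log units; beyond the scatter). That step exchanges 4-hydroxypiperidin-1-yl for 3-hydroxyazetidin-1-yl and keeps the hydroxy, so no measurement tests the replacement itself. Its modest size is therefore a loose guide, and the data do not settle the direction. A modest rise in this assay is tentatively expected, rather than a large move. The expected change is a 2.2-fold higher number from compound 2 to compound 4 (0.35 log units; beyond the scatter). For compound 4 the estimated value is 220000 nM, with an expected range of 60000 nM to 600000 nM.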

Compound 4, solubility: 500000 nM
The estimate for compound 4 lay 2.3-fold (0.36 log units) below the measured number; measured number inside the range.
By their numbers in this assay, from the lowest: compound 3; then compound 2; then compounds 1 and 4 (each within the scatter of the next).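

Hydroxy on this saturated ring carbon, three ring bonds from the ring nitrogen, is not required for a high number in this assay: dimethylamino in its place gives a 5.1-fold higher number from compound 2 to compound 4 (0.70 log units; beyond the scatter) and brings no hydrogen-bond donor. Among the compounds shown here, this is the first measured change of the group itself, as the earlier step kept the hydroxy. Exchanging 3-hydroxyazetidin-1-yl for 4-(dimethylamino)piperidin-1-yl in a single step gives a 12-fold higher number from compound 3 to compound 4 (1.09 log units; beyond the scatter) and this large move joins the change of ring size to the change of group.

The compounds shown leave open how much of that large move comes from each part, which 3-(dimethylamino)azetidin-1-yl would separate. They also leave open whether the rise needs the amine at all, which methoxy at the same carbon would test. No evidence given here accounts for either step.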